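Changing the outer ring on a shared urea core

The source may report more compounds than this note shows. Statements on the series, on what has been measured and on what is new or still open speak of the compounds shown alone.

Compound 1 `COc1ccc(Br)cc1Nc1cc(NC(=O)Nc2c(Cl)cccc2Cl)ncn1` and compound 2 `COc1ccc(OC)c(Nc2cc(NC(=O)Nc3c(Cl)cccc3Cl)ncn2)c1` share the same core and differ in a single group on the outer aromatic ring. In a functional assay on HCC827 cells (Homo sapiens) for inhibition, read by MTT assay, with a stated time of 48 h, tested at 10 uM (on this read-out higher numbers stand for more inhibition at the one concentration tested (going by the name of the read-out) and lower numbers for less inhibition), compound 1 gives 53%, the lowest of the two numbers shown, and compound 2 gives 94.1%. Going by the values given here, the one measured step, a number 41.1 percentage points higher from compound 1 to compound 2 (beyond the scatter), shows that a single change on that outer ring can move the read-out far beyond the usual scatter.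

Compound 3 `Cc1ccc(Nc2cc(NC(=O)Nc3c(Cl)cccc3Cl)ncn2)cc1F` carries a different outer ring altogether: 3-fluoro-4-methylphenyl in place of 5-bromo-2-methoxyphenyl on a nitrogen on an aromatic ring. Among the compounds with values here, no measured step matches this change. The step from compound 1 to compound 2 bears on it only indirectly, in showing how much this read-out responds to the groups on that ring, and it gives no direction for a ring that loses both the methoxy and the bromo and gains a fluoro and a methyl instead. The step expected in this assay is a number 7 percentage points higher from compound 1 to compound 3 (within the scatter), with wide uncertainty in both directions. Compound 3 is estimated at 60%, between 25% and 95%.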

Compound 3, a percentage reported as inhibition, at one concentration (the size of the read-out at that concentration, not a potency): 85.3%
Beside the measured number, compound 3's estimate is 25.3 percentage points below it; low and high end bracket the measured number.
By their numbers in this assay, from the lowest: compound 1; then compounds 3 and 2 (each within the scatter of the next).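

In this assay, the step of a number 32.3 percentage points higher from compound 1 to compound 3 (beyond the scatter) shows that the outer ring on this nitrogen does not need a methoxy or a bromo to give a high number, since 3-fluoro-4-methylphenyl carries neither. Compound 2 keeps a methoxy and compound 3 has none, yet their numbers lie within the scatter of each other, so two differently substituted rings land in the same range and, among these three, only compound 1 with its 5-bromo-2-methoxyphenyl stands clearly apart. Nothing available explains why this ring gives so much less inhibition than the other two.

Since the fluoro and the methyl enter together while the bromo and the methoxy leave together, it remains open which of these groups accounts for the step, and a ring carrying only the fluoro or only the methyl would help to separate them. On these data alone, it also remains open how this read-out would respond to an amine or a carboxylic acid on the outer ring, or to an ethyl group in place of the methyl.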